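The compounds below may be only part of what the source reports. "The series", "measured", "known", "first", "only" and "open" are said of these compounds alone.

Compound 1 `C=C[C@@](C)(/C=C/c1ccc(O)c(/C=C/C(=O)OCC)c1)CCC=C(C)C`: 20900 nM
Compound 2 `C=C[C@@](C)(/C=C/c1ccc(O)c(/C=C/C(=O)O)c1)CCC=C(C)C`: > 43400 nM

In a functional assay on NALM-6 cells (Homo sapiens) for cytotoxicity, with a stated time of 72 h (a lower number here means that less compound is needed, a higher number that more compound is needed for the effect), compound 1 gives 20900 nM. For compound 2 only a limit of the assay is known in this assay, namely > 43400 nM, which is the limit of > 43400 nM in this assay, at which 1 of the 2 values shown sits. Compound 2 thus stands at the upper end of the two numbers shown, and the step of an at least 2.0-fold higher number from compound 1 to compound 2 (0.31 log units; beyond the scatter) records how far behind compound 1 it falls.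

Compound 3 `C=C[C@@](C)(/C=C/c1ccc(O)c(/C=C(\C)C(=O)OCC)c1)CCC=C(C)C` carries 2-(ethoxycarbonyl)prop-1-en-1-yl in place of 2-carboxyethenyl on an aromatic carbon. This change restores the ethyl ester that compound 2 lacks and, in addition, places a methyl on the double bond. Within the data shown here, the only measured step that bears on it is an at least 2.0-fold higher number from compound 1 to compound 2 (0.31 log units; beyond the scatter), which runs in the opposite direction: removing the ethyl raised the number beyond the scatter. Returning it is therefore expected to lower the number again by a step of roughly the same size, so that the estimated step is an at least 2.1-fold lower number from compound 2 to compound 3 (0.33 log units; beyond the scatter). The added methyl has no counterpart among the measured compounds, so nothing shown speaks for or against it. Near compound 1, then, compound 3 is expected to give 20000 nM, with a range from 8000 nM to 50000 nM.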

Compound 3, half-maximal effective concentration: > 7500 nM
Compound 3 was reported as a limit; the forecaster's own chance of this, stated with the estimate: 25%; the middle value does not contradict the limit.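

In this assay compound 3 is reported only as a limit, > 7500 nM, so neither its step from compound 2 nor its step from compound 1 can be read. The compounds shown leave open how 2-(ethoxycarbonyl)prop-1-en-1-yl in compound 3 compares with 2-(ethoxycarbonyl)ethenyl in compound 1 in this assay.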